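Aryl swap on the enone arm: outlook for compound 4

This account rests on a few compounds, and the source may have more. Where it says the series, first, only, none or still open, it means among the compounds named here.

Measured compounds:
compound 1 `COc1cccc(/C=C/C(=O)c2ccc(OCCn3cc(CN4C(=O)/C=C/C(C)(C)C/C=C(\C)CC/C=C/4C)nn3)cc2O)c1` gives 0.61 ug/mL
compound 2 `C/C1=C\CC(C)(C)/C=C/C(=O)N(Cc2cn(CCOc3ccc(C(=O)/C=C/c4ccc(C(C)C)cc4)c(O)c3)nn2)/C(C)=C/CC1` gives 0.77 ug/mL
compound 3 `COc1ccc(/C=C/C(=O)c2ccc(OCCCN3C(=O)/C=C/C(C)(C)C/C=C(\C)CC/C=C/3C)cc2)cc1` gives 2.56 ug/mL

In a functional assay on Lu cells (Homo sapiens) for antiproliferative activity (a higher number here means a weaker inhibitor, a lower number a stronger inhibitor), compound 3 stands highest of the three numbers; its gap to compound 2 and to compound 1 lies beyond the scatter, so compound 3 is the weakest inhibitor here.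

Compound 4 `COc1cc(/C=C/C(=O)c2ccc(OCCCN3C(=O)/C=C/C(C)(C)C/C=C(\C)CC/C=C/3C)cc2)cc(OC)c1OC` is not yet measured. It differs from compound 3 by 3,4,5-trimethoxyphenyl in place of 4-methoxyphenyl on a double-bonded chain carbon bound to a double-bonded chain carbon.

Going by the values given here, the only measured step that bears on an aryl exchange at this place is a 1.3-fold higher number from compound 1 to compound 2 (0.10 log units; within the scatter), which was within the scatter, though it was made on a core unlike that of compound 3. The expected step of a 1.2-fold lower number from compound 3 to compound 4 (0.07 log units; within the scatter) is therefore small, no clear direction. Compound 4 is estimated at 2.2 ug/mL, range 0.8 ug/mL to 6 ug/mL.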

Compound 4, half-maximal inhibitory concentration: 1.01 ug/mL
Beside the measured number, compound 4's estimate is 2.2-fold (0.34 log units) above it; the measured number falls inside the stated range.
By their numbers in this assay, from the lowest: compounds 1, 2 and 4 (each within the scatter of the next); then compound 3.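

On the core of compound 3, the aryl group at this position changes the number in this assay: 3,4,5-trimethoxyphenyl in place of 4-methoxyphenyl gives a 2.5-fold lower number from compound 3 to compound 4 (0.40 log units; beyond the scatter). Going by these compounds alone, the earlier aryl exchange on the other core, a 1.3-fold higher number from compound 1 to compound 2 (0.10 log units; within the scatter), gave no step beyond the scatter, so sensitivity at this position is seen only on the core of compound 3. No measurement available here accounts for this step. From the compounds shown here alone, whether 3,4,5-trimethoxyphenyl has the same effect on the core of compound 1 remains open. Also open, going by these compounds, is what a dimethylamino or carboxylic acid group on this aryl ring would do.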